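The source may report more compounds than this note shows. Statements on the series, on what has been measured and on what is new or still open speak of the compounds shown alone.

Measured compounds:
Compound 1 `COc1cc2ncnc(Nc3ccc(C)cc3)c2cc1OCCCCC(=O)Nc1ccc(S(N)(=O)=O)cc1`, 19300 nM in a functional assay on NCI-H1975 cells (Homo sapiens) for antiproliferative activity, read by MTT assay, with a stated time of 72 h; on this read-out higher numbers stand for weaker inhibition and lower numbers for stronger inhibition
Compound 2 `CCc1ccc(Nc2ncnc3cc(OC)c(OCCCCC(=O)Nc4ccc(S(N)(=O)=O)cc4)cc23)cc1`, 10300 nM in this assay
Compound 3 `Cc1ccc(Nc2ncnc3ccc(NC(=S)Nc4ccc(S(N)(=O)=O)cc4)cc23)cc1`, 39400 nM in this assay

Compound 1 and compound 2 share one core and differ only by methyl in place of hydrogen on a saturated chain carbon bound to an aromatic carbon. That change gave a 1.9-fold lower number from compound 1 to compound 2 (0.27 log units; within the scatter). Compound 3 carries a different core; how it differs from the core of compound 1 is not broken down here. Compound 3 gives the highest of the three numbers, a number beyond the scatter away from compound 1 and from compound 2.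

Compound 4 `CCc1ccc(Nc2ncnc3ccc(NC(=S)Nc4ccc(S(N)(=O)=O)cc4)cc23)cc1` has not yet been measured in this assay. It differs from compound 3 by methyl in place of hydrogen on a saturated chain carbon bound to an aromatic carbon, the same change that was made from compound 1 to compound 2. Since the place of the change is the same in both pairs, the step from compound 3 to compound 4 is expected to be of a size similar to the earlier one, that is, a change that stays within the scatter. On that basis the step is estimated as a 1.8-fold lower number from compound 3 to compound 4 (0.25 log units; within the scatter). For compound 4 in this assay the estimate is 22000 nM, with a range from 9000 nM to 55000 nM.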

Compound 4, half-maximal inhibitory concentration: 38700 nM
Beside the measured number, compound 4's estimate is 1.8-fold (0.25 log units) below it, and the stated range covers the measured number.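

Carried onto the core of compound 3, the change from 4-methylphenyl to 4-ethylphenyl gave a 1.0-fold lower number from compound 3 to compound 4 (0.01 log units; within the scatter) in this assay. Set beside the earlier step, the two cores cannot be told apart in how they take this change: the same change on two cores in this assay, a 1.9-fold lower number (0.27 log units; within the scatter) from compound 1 to compound 2 and a 1.0-fold lower number (0.01 log units; within the scatter) from compound 3 to compound 4, 1.8-fold (0.26 log units) apart, within the scatter of two such steps. On both cores the step stays within the scatter, so the pair gives no sign that the outcome of this change depends on the core; it does not show that the change has a real effect on either core, and two pairs of compounds cannot establish a rule for the whole series.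

The compounds shown leave open whether a longer chain such as propyl or butyl in the same place on the phenyl ring would move the number beyond the scatter on either core. They also leave open how a chlorine atom or a methoxy group there would compare with methyl and ethyl.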